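The source may report more compounds than this note shows. Statements on the series, on what has been measured and on what is new or still open speak of the compounds shown alone.

Measured so far:
compound 1 `COc1cccc(-c2cc3c(n2-c2ccc(O)c(C(=O)O)c2)CCCC3)c1` — 20%
compound 2 `O=C(O)c1cc(-n2c(-c3ccc(Cl)cc3)cc3c2CCCC3)ccc1O` — 40%

Within the data shown here, compound 2 stands highest of the two values in a functional assay on the whole organism (strain Wistar) for inhibition, with Rattus norvegicus as the target, read by paw edema, with stated times of 30 min and 3 h, at a dose of 200 mg/kg by the oral route; a higher number here means more inhibition at the dose given (going by the name of the read-out), a lower number less inhibition; the only step available is a number 20 percentage points higher from compound 1 to compound 2 (beyond the scatter), a modest change on swapping one aryl group for another. Compound 3 `O=C(O)c1cc(-n2c(-c3ccc([N+](=O)[O-])cc3)cc3c2CCCC3)ccc1O` differs from compound 2 by nitro in place of chloro on an aromatic carbon. Among the measured compounds shown here, no measured step exchanges chloro for nitro, so the one step known bears on this change only loosely, and no shift beyond the scatter is expected for compound 3 in this assay. Compound 3 is estimated at 40%, range 20% to 60%, an expected step of no change at the digits printed from compound 2 to compound 3 (within the scatter).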

Compound 3, a percentage reported as inhibition, in the whole organism at one dose (the size of the read-out at that dose, not a potency): 30%
For compound 3 the middle estimate is 10 percentage points above the measured one; the measured number falls inside the stated range.
By their numbers in this assay, from the lowest: compounds 1, 3 and 2 (each within the scatter of the next, the first and the last beyond it).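

In this assay, nitro in place of chloro on this aromatic carbon gives a number 10 percentage points lower from compound 2 to compound 3 (within the scatter), so the position para to a large group accepts either group within the resolution of this read-out. Replacing the 3-methoxyphenyl group with 4-nitrophenyl gives a number 10 percentage points higher from compound 1 to compound 3 (within the scatter), whereas the 4-chlorophenyl swap gives a number 20 percentage points higher from compound 1 to compound 2 (beyond the scatter). No available data account for either difference.

Going by these compounds, it remains open how an amine or a carboxylic acid at this position would read, and whether a 4-methoxyphenyl group would read like 3-methoxyphenyl.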